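The source may report more compounds than this note shows. Statements on the series, on what has been measured and on what is new or still open speak of the compounds shown alone.

In a functional assay on MCF7 cells (Homo sapiens) for cytotoxicity, read by MTT assay, with a stated time of 72 h (on this read-out lower numbers stand for stronger inhibition and higher numbers for weaker inhibition), compound 1 (`COc1ccc(/C=C2\CCC/C(=C\c3cccc(OC)c3OC)C2=O)cc1`) gives 18600 nM while compound 2 (`COc1ccc(/C=C2\CCC/C(=C\c3cccc(OC)c3OC)C2=O)cc1OC`) gives 6500 nM and compound 3 (`COc1cc(/C=C2\CCC/C(=C\c3cccc(OC)c3OC)C2=O)ccc1O`) gives 11600 nM in the same test. Compound 2 has the lower number against compound 1 (beyond the scatter, a 2.9-fold lower number from compound 1 to compound 2 (0.46 log units; beyond the scatter)) and stays within the scatter of compound 3 (a 1.8-fold higher number from compound 2 to compound 3 (0.25 log units; within the scatter)). Compound 4 (`COc1ccccc1/C=C1\CCC/C(=C\c2ccc(OC)c(OC)c2)C1=O`) differs from compound 2 by hydrogen in place of methoxy on an aromatic carbon (hydrogen in place of methoxy on an aromatic carbon, ortho to a methoxy group and meta to a large group). The nearest measured precedent is the modest step of a 2.9-fold lower number from compound 1 to compound 2 (0.46 log units; beyond the scatter) where a methoxy replaces hydrogen, read here in reverse and at a different place in the structure. The step of a 1.8-fold higher number from compound 2 to compound 3 (0.25 log units; within the scatter) is a different change and gives little guidance. A modest move to a higher number is therefore expected in this assay and may not clear the scatter. The expected change is a 1.7-fold higher number from compound 2 to compound 4 (0.23 log units; within the scatter) for this pair. For compound 4 the estimated value is 11000 nM (expected range 4500 nM to 26000 nM).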

Compound 4, half-maximal inhibitory concentration: 8000 nM
Estimate against measurement, compound 4: 1.4-fold (0.14 log units) above, and the stated range covers the measured number.
By their numbers in this assay, from the lowest: compounds 2, 4, 3 and 1 (each within the scatter of the next, the first and the last beyond it).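

In this assay, the change at this place gives a 1.2-fold higher number from compound 2 to compound 4 (0.09 log units; within the scatter), so hydrogen in place of methoxy, ortho to a methoxy group and meta to a large group, cannot be told from the scatter. The earlier methoxy step at a different place in the structure, a 2.9-fold lower number from compound 1 to compound 2 (0.46 log units; beyond the scatter), lies beyond the scatter, so within these compounds the effect of a methoxy depends on where it stands, although this rests on only these two steps. No measurement shown here accounts for the contrast between the two places.

As far as these compounds go, whether an amine, a carboxylic acid or a longer chain such as ethoxy at this position would move the number beyond the scatter remains open. Also open, from the compounds shown here alone, is what happens when the methoxy group remaining on the same ring is replaced.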